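This account rests on a few compounds, and the source may have more. Where it says the series, first, only, none or still open, it means among the compounds named here.

In a functional assay on HOP-62 cells (Homo sapiens) for inhibition, read by sulforhodamine B assay, with a stated time of 48 h, tested at 10 uM (a higher number here means a weaker effect of the compound at the concentration tested, a lower number a stronger effect), the three measured compounds gave the following numbers:

Compound 1 `O=C(Nc1cccc(-n2cc(-c3ccncc3)c(-c3cc(O)cc(Cl)c3)n2)c1)Nc1ccc(Cl)c(C(F)(F)F)c1`: 8.99%
Compound 2 `O=C(Nc1cccc(-n2cc(-c3ccncc3)c(-c3cc(O)cc(Cl)c3)n2)c1)Nc1ccc(Cl)c(Cl)c1`: -44.2%
Compound 3 `COc1cc(Cl)cc(-c2nn(-c3cccc(NC(=O)Nc4cc(C(F)(F)F)cc(C(F)(F)F)c4)c3)cc2-c2ccncc2)c1`: -41.1%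

Compound 3 stands second highest of the three. Its nearest neighbour is compound 2, whose number lies within the scatter of it; its furthest is compound 1, whose number lies beyond the scatter above it. Among the measured compounds shown here, the only measured step between compounds that differ in one place is the one from compound 1 to compound 2, chloro in place of trifluoromethyl on an aromatic carbon, which gave a number 53.2 percentage points lower from compound 1 to compound 2 (beyond the scatter).

Compound 4 `COc1cc(Cl)cc(-c2nn(-c3cccc(NC(=O)Nc4cccc(C(F)(F)F)c4)c3)cc2-c2ccncc2)c1` differs from compound 3 by hydrogen in place of trifluoromethyl on an aromatic carbon. That step also removes a trifluoromethyl, but puts a hydrogen in its place rather than a chloro, so the step from compound 1 to compound 2 bears on it only loosely. A modest step upward is expected, close to the scatter, giving a number 21.1 percentage points higher from compound 3 to compound 4 (beyond the scatter). Compound 4 is therefore expected to give about -20%, between -60% and 20%.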

Compound 4, a percentage reported as activity, at one concentration (the size of the read-out at that concentration, not a potency): 15.5%
Compound 4: middle estimate off by 35.5 percentage points, on the low side; measured number inside the range.
By their numbers in this assay, from the lowest: compounds 2 and 3 (each within the scatter of the next); then compounds 1 and 4 (each within the scatter of the next).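

In this assay, replacing one trifluoromethyl with hydrogen gave a number 56.6 percentage points higher from compound 3 to compound 4 (beyond the scatter), so at this place, meta to a trifluoromethyl group, the second trifluoromethyl accompanies the stronger effect and its replacement by hydrogen weakens it markedly. The earlier step, with chloro entering in place of trifluoromethyl, ran the opposite way, giving a number 53.2 percentage points lower from compound 1 to compound 2 (beyond the scatter), so across these two steps, which sit on different compounds, losing a trifluoromethyl does not by itself set the direction of change. Nothing measured here explains why either step goes the way it does.

Going by these compounds, it remains open whether a chloro, a methyl or a methoxy at this same place on compound 3 would keep the stronger effect. On these data alone, whether hydrogen in place of trifluoromethyl would act the same way on the core of compound 1 also remains open.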